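The source may report more compounds than this note shows. Statements on the series, on what has been measured and on what is new or still open speak of the compounds shown alone.

Measured so far:
compound 1 `O=C(CCCCCCCC(=O)c1ccc(Br)cc1)NO` — 45 nM
compound 2 `O=C(CCCCCCC/C(=N\O)c1ccc2ccccc2c1)NO` — 8.5 nM

In an assay on isolated protein for inhibition of histone deacetylase 8 (Homo sapiens) (a higher number here means a weaker inhibitor, a lower number a stronger inhibitor), compound 1 gives 45 nM, the higher of the two numbers; compound 2 gives 8.5 nM, a lower number beyond the scatter. Among the measured compounds shown here, the two differ in more than one place, so no single step connects them.

Compound 3 `O=C(CCCCCCCC(=O)c1ccc(N2CCCCC2)cc1)NO` is not yet measured. Relative to compound 1 the change is piperidin-1-yl in place of bromo on an aromatic carbon. For the measured compounds named here, no measured pair isolates this change. The step of a 1.5-fold lower number from compound 1 to compound 3 (0.18 log units; within the scatter) is expected to be modest, toward a lower number, and may stay within the scatter. Compound 3 is expected to give 30 nM, in the range 8 nM to 110 nM.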

Compound 3, half-maximal inhibitory concentration: 9.5 nM
Beside the measured number, compound 3's estimate is 3.2-fold (0.50 log units) above it, within the range that was stated.
By their numbers in this assay, from the lowest: compounds 2 and 3 (each within the scatter of the next); then compound 1.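

In this assay, among the compounds shown here, piperidin-1-yl in place of bromo on an aromatic carbon gives a 4.7-fold lower number from compound 1 to compound 3 (0.68 log units; beyond the scatter), the first single-place step. This position therefore accepts a six-membered non-aromatic ring in place of a single bromine atom without any loss, and the number falls beyond the scatter. No available evidence bears on what drives this step. Still open, on these data alone, is whether the ring itself matters or only its nitrogen, which a morpholine ring or a dimethylamino group at this carbon would test. Also open, as far as these compounds go, is whether the step carries over to the core of compound 2.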